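A few compounds are considered here, and "the series" means these few. Any claim that something is new, unique, unknown or untested is made for them only; others in the source may bear on it.

Measured set in an ADME assay on HT-29 cells (Homo sapiens) for inhibition, read by MTT assay, with a stated time of 72 h; on this read-out higher numbers stand for weaker inhibition and lower numbers for stronger inhibition:
compound 1 `Nc1cccc(Nc2nc(N/N=C/c3ccc(F)cc3)ncc2Cl)c1` gives 12300 nM
compound 2 `COc1ccc(/C=N/Nc2ncc(Cl)c(Nc3cccc(NC(=O)/C=C/CN(C)C)c3)n2)cc1` gives 4820 nM
compound 3 `CN(C)C/C=C/C(=O)Nc1cccc(Nc2nc(N/N=C/c3cn(Cc4ccccc4)c4ccccc34)ncc2Cl)c1` gives 2120 nM

Compound 2 holds the second highest of the three numbers in this assay; compound 3 sits lower and compound 1 higher, and each of those gaps lies beyond the scatter. Compound 4 `COc1ccc(/C(C)=N/Nc2ncc(Cl)c(Nc3cccc(NC(=O)/C=C/CN(C)C)c3)n2)cc1` is the unmeasured member. It differs from compound 2 by a group of 11 heavy atoms (9 carbon, 1 nitrogen, 1 oxygen; one six-membered aromatic ring of carbon only) in place of a group of 10 heavy atoms (8 carbon, 1 nitrogen, 1 oxygen; one six-membered aromatic ring of carbon only), on a nitrogen on an aromatic ring. Among the compounds with values here, no measured pair in the set carries this change, so there is no step to lean on. The change is expected to shift the number in this assay by no more than the scatter, in no settled direction, the step being estimated as a 1.1-fold lower number from compound 2 to compound 4 (0.03 log units; within the scatter). Compound 4 is expected to give 4500 nM, with a range from 1500 nM to 13000 nM.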

Compound 4, half-maximal inhibitory concentration: 6830 nM
Beside the measured number, compound 4's estimate is 1.5-fold (0.18 log units) below it; the measured number falls inside the stated range.
By their numbers in this assay, from the lowest: compound 3; then compounds 2, 4 and 1 (each within the scatter of the next, the first and the last beyond it).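

In this assay, within the data shown here, the group of 11 heavy atoms in place of the group of 10 heavy atoms, on a nitrogen on an aromatic ring, gives a 1.4-fold higher number from compound 2 to compound 4 (0.15 log units; within the scatter) as the first step in the set between compounds differing in one place. At this position, then, the change leaves no shift that can be told from the scatter. Nothing measured here bears on this result.

Still open, going by these compounds, is how this position answers to a group carrying an amine, a carboxylic acid or a longer chain. On these data alone, whether the same step holds on the core of compound 1 or compound 3 also remains unknown.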